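The compounds below may be only part of what the source reports. "The series", "measured", "known", "first", "only" and "open" are said of these compounds alone.

Measured compounds:
Compound 1 `COc1cc(C)cc(-c2c(-c3ccnc(-c4ccc(C(C)=O)cc4)c3)cnn2CC#N)c1` gives in a functional assay on LOX IMVI cells (Homo sapiens) for inhibition, read by sulforhodamine B assay, with a stated time of 48 h (on this read-out lower numbers stand for higher toxicity in this test and higher numbers for lower toxicity in this test), a result of > 100000 nM, which is a limit of the assay and not a number.
Compound 2 `Cc1cc(O)cc(-c2nn(CC#N)cc2-c2ccnc(-c3ccc(Oc4ccccc4)cc3)c2)c1` gives in this assay a value of 6130 nM.
Compound 3 `COc1cc(C)cc(-c2nn(CC#N)cc2-c2ccnc(-c3ccc(N(C)C)cc3)c2)c1` gives in this assay a result of > 100000 nM, again a limit of the assay and not a number.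

Compound 3 therefore stands at the limit of > 100000 nM in this assay, at which 2 of the 3 values shown sit, and no measured number places it against compound 2. Compound 2 is the only one of the three that returns a number at all; the others stop at the limit. No pair of these compounds differs in a single place, so no measured step is available.

Compound 4 `Cc1cc(O)cc(-c2nn(CC#N)cc2-c2ccnc(-c3ccc(N(C)C)cc3)c2)c1` differs from compound 3 by hydrogen in place of methyl on an oxygen on an aromatic ring. Compound 2 carries the same hydroxy group as compound 4 and gives a number, while compound 1 and compound 3, each with the methoxy group, sit at the limit; but compound 2 also differs from compound 4 elsewhere, so this is a hint rather than a measured step. He expects the step of an at least 3.3-fold lower number from compound 3 to compound 4 (0.52 log units; beyond the scatter) to run toward higher toxicity, though with a fair chance that compound 4 again reaches only the limit. His estimate for compound 4 in this assay is 30000 nM, between 5000 nM and 100000 nM.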

Compound 4, concentration lethal to 50% of the cells: 47700 nM
Compound 4: the middle estimate sits 1.6-fold (0.20 log units) below what was measured; measured number inside the range.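

Hydrogen in place of methyl on an oxygen on an aromatic ring gives an at least 2.0-fold lower number from compound 3 to compound 4 (0.32 log units; beyond the scatter) in this assay, so with the dimethylamino group in place, the change from methoxy to hydroxy turns a limit into a number. With the hydroxy group held fixed, dimethylamino in place of phenoxy on an aromatic carbon gives a 7.8-fold higher number from compound 2 to compound 4 (0.89 log units; beyond the scatter) in this assay, which shows that the group at this second place also moves the number, here toward lower toxicity in this test. The first step is bounded on one side only, since the result for compound 3 is a limit of the assay and not a number: the limit of > 100000 nM in this assay, at which 2 of the 4 values shown sit.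

The compounds shown leave open how large the methoxy to hydroxy step really is, and whether the same change would bring compound 1, which also sits at the limit, down to a number. They also leave open what an ethoxy group in place of the methoxy, or a primary amine or a carboxylic acid in place of the dimethylamino, would give in this assay.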